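Second fluoro on the aryl of compound 2: expected inhibition

The source may report more compounds than this note shows. Statements on the series, on what has been measured and on what is new or still open speak of the compounds shown alone.

The series shares one core. Compound 1 `CC(C)(C)Cc1c(-c2cccnc2)sc(N)c1C(=O)c1ccc(Cl)cc1` carries pyridin-3-yl, compound 2 `CC(C)(C)Cc1c(-c2ccc(F)cc2)sc(N)c1C(=O)c1ccc(Cl)cc1` carries 4-fluorophenyl. In an assay on CHO cells for displacement of a labelled ligand from adenosine receptor A3 (Homo sapiens), read by scintillation counting, tested at 10 uM (on this read-out lower numbers stand for less inhibition and higher numbers for more inhibition at the one concentration tested (going by the name of the read-out)), compound 1 gives 1%, and compound 2 gives 9%. As the two numbers stand, compound 2 sits at the top, yet the step of a number 8 percentage points higher from compound 1 to compound 2 (within the scatter) lies within the scatter, so the two compounds are not separated by the data. Compound 3 `CC(C)(C)Cc1c(-c2ccc(F)cc2F)sc(N)c1C(=O)c1ccc(Cl)cc1` differs from compound 2 by fluoro in place of hydrogen on an aromatic carbon. Among the compounds with values here, the only measured step, a number 8 percentage points higher from compound 1 to compound 2 (within the scatter), exchanged one aryl group for another and does not bear directly on adding a fluoro; it was small in any case. Nothing measured here speaks for a move beyond the scatter, so the expected step in this assay is a number 1 percentage points higher from compound 2 to compound 3 (within the scatter), roughly none. Compound 3 is therefore estimated at 10%, with a range from 0% to 25%.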

Compound 3, a percentage reported as inhibition, at one concentration (the size of the read-out at that concentration, not a potency): 1%
The estimate for compound 3 lay 9 percentage points above the measured number; measured number inside the range.
By their numbers in this assay, from the lowest: compounds 1, 3 and 2 (each within the scatter of the next).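

Adding a second fluoro, ortho to a large group and meta to the existing fluoro, gives in this assay a number 8 percentage points lower from compound 2 to compound 3 (within the scatter), so this change on this aromatic carbon does not separate 2,4-difluorophenyl from 4-fluorophenyl. The comparison with the pyridin-3-yl group gives no change at the digits printed from compound 1 to compound 3 (within the scatter), which leaves all three aryl groups on the shared core unseparated at the one concentration tested. No evidence is available that would account for these numbers.

As far as these compounds go, whether an amine or a carboxylic acid on this aryl group would give a step beyond the scatter in this assay stays open. Also open, from the compounds shown here alone, is whether a longer chain at this position, in place of the aryl group, would leave the number where it stands.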